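Adding a Third Trifluoromethyl Group to an Aryl Ether

The source may hold more compounds than are shown below. What is called first, only, known or untested is meant among the compounds shown, and "the series" means these compounds.

Compound 1 `CC(O)(COc1cccc(C(F)(F)F)c1)C(=O)Nc1cccc(S(F)(F)(F)(F)F)c1` gives 28900 nM in a functional assay on CWR22R cells (Homo sapiens) for antiproliferative activity, read by propidium iodide staining, with a stated time of 96 h; a lower number here means a stronger inhibitor, a higher number a weaker inhibitor.
Compound 2 `CC(O)(COc1ccc(C#N)cc1)C(=O)Nc1cccc(S(F)(F)(F)(F)F)c1` gives 32500 nM in this assay.
Compound 3 `CC(O)(COc1ccc(C#N)cc1C(F)(F)F)C(=O)Nc1cccc(S(F)(F)(F)(F)F)c1` gives 18300 nM in this assay.

Compounds 1 and 2 share a core and differ by 3-(trifluoromethyl)phenyl in place of 4-cyanophenyl on an oxygen on a saturated carbon; the step is a 1.1-fold higher number from compound 1 to compound 2 (0.05 log units; within the scatter). From compound 2 to compound 3 the change is trifluoromethyl in place of hydrogen on an aromatic carbon, giving a 1.8-fold lower number from compound 2 to compound 3 (0.25 log units; within the scatter). Compound 4 `CC(O)(COc1cc(C(F)(F)F)cc(C(F)(F)F)c1)C(=O)Nc1cccc(S(F)(F)(F)(F)F)c1` is not yet measured and differs from compound 1 by trifluoromethyl in place of hydrogen on an aromatic carbon. This is the same kind of change as that from compound 2 to compound 3, but the surroundings differ: there the new group sits ortho to a large group and meta to a cyano group, here meta to a large group and meta to a trifluoromethyl group. Because the earlier step was a 1.8-fold lower number from compound 2 to compound 3 (0.25 log units; within the scatter), the step from compound 1 to compound 4 is expected to be about a 1.5-fold lower number from compound 1 to compound 4 (0.18 log units; within the scatter). Compound 4 is therefore estimated at 19000 nM, likely between 8000 nM and 42000 nM.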

Compound 4, half-maximal inhibitory concentration: 6500 nM
Compound 4: the middle estimate sits 2.9-fold (0.47 log units) above what was measured; the measured number lies below the stated range.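

In this assay the added trifluoromethyl gives a 4.4-fold lower number from compound 1 to compound 4 (0.65 log units; beyond the scatter) and this step stands clear of the usual scatter. Set beside the earlier case, the direction is the same and the gap between the two steps is no larger than repeat measurements could produce, so the change carries over between these two cores as far as can be told: the same change on two cores in this assay, a 1.8-fold lower number (0.25 log units; within the scatter) from compound 2 to compound 3 and a 4.4-fold lower number (0.65 log units; beyond the scatter) from compound 1 to compound 4, 2.5-fold (0.40 log units) apart, within the scatter of two such steps. This does not show that the step would be the same size on any other core, and two pairs cannot explain the gap between them.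

The compounds shown leave open whether a methyl group, a chlorine atom or an amine in place of that hydrogen on compound 1 would give a similar number.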